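Nitro in place of amino: working notes

This account rests on a few compounds, and the source may have more. Where it says the series, first, only, none or still open, it means among the compounds named here.

Compound 1 `COc1cc(C(=O)/C=C/c2c[nH]c3ccccc23)cc([N+](=O)[O-])c1OC`: 1280 nM
Compound 2 `COc1cc(C(=O)/C=C/c2cn(C)c3ccccc23)cc(SC)c1OC`: 193 nM
Compound 3 `COc1cc(C(=O)/C=C/c2cn(C)c3ccccc23)cc(N)c1OC`: 441 nM

All three values come from a functional assay on A2780 cells (Homo sapiens) for antiproliferative activity, read by MTT assay, with a stated time of 48 h; a lower number here means a stronger inhibitor, a higher number a weaker inhibitor. Compound 3 at 441 nM holds the middle place of the three numbers, higher than compound 2 and lower than compound 1.

The next compound to be measured is compound 4 `COc1cc(C(=O)/C=C/c2cn(C)c3ccccc23)cc([N+](=O)[O-])c1OC`, with nitro in place of amino on an aromatic carbon. The group sits ortho to a methoxy group and meta to a large group.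

One measured step changes this same place: a 2.3-fold higher number from compound 2 to compound 3 (0.36 log units; beyond the scatter), a modest step on amino in place of methylsulfanyl. It shows that this place can move the number, but it says nothing directly about nitro. Compound 1 does carry nitro and stands at 1280 nM, but its core lacks the methyl group of compound 4, so it serves only as a loose upper guide.

A step of similar or smaller size towards a higher number is therefore expected in this assay, estimated as a 1.4-fold higher number from compound 3 to compound 4 (0.13 log units; within the scatter).

For compound 4 the estimated value is 600 nM, with an expected range from 200 nM to 1800 nM.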

Compound 4, half-maximal inhibitory concentration: 1890 nM
For compound 4 the middle estimate is 3.2-fold (0.50 log units) below the measured one, and the stated range ends below it.
By their numbers in this assay, from the lowest: compound 2; then compound 3; then compounds 1 and 4 (each within the scatter of the next).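

In this assay this aromatic carbon, ortho to a methoxy group, proves more sensitive than the earlier pair suggested: on the shared core, nitro gives a 4.3-fold higher number from compound 3 to compound 4 (0.63 log units; beyond the scatter) when it replaces amino and a 9.8-fold higher number from compound 2 to compound 4 (0.99 log units; beyond the scatter) when it replaces methylsulfanyl. Of the three groups compared at this position, nitro therefore carries the highest number, with both of its steps beyond the scatter. The methyl in place of hydrogen on the aromatic nitrogen gives a 1.5-fold higher number from compound 1 to compound 4 (0.17 log units; within the scatter) and so does not separate these two nitro compounds, which means the earlier doubt about using compound 1 as a guide no longer weighs heavily; no measurement shown accounts for the size of the nitro step.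

The compounds shown place only methylsulfanyl, amino and nitro on this carbon, so it remains open where a hydroxyl group or a carboxylic acid would fall. Hydrogen and methyl on the aromatic nitrogen are compared only with nitro in place, so it also remains open whether that methyl matters as little with amino or methylsulfanyl at this position.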